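Aryl exchange on the shared core: compound 3 to compound 4

The source may report more compounds than this note shows. Statements on the series, on what has been measured and on what is new or still open speak of the compounds shown alone.

In a functional assay on KB cells (Homo sapiens) for antiproliferative activity, read by sulforhodamine B assay, with a stated time of 3 days (a lower number here means that less compound is needed, a higher number that more compound is needed for the effect), compound 1 `CCC1=C(O)c2c(oc(-c3ccc(C(C)C)cc3)cc2=O)C(CC)(CC)C1=O` gives 8.13 uM and compound 3 `CCC1=C(O)c2c(oc(-c3ccccc3OC)cc2=O)C(CC)(CC)C1=O` gives 40.8 uM. That is the higher of the two numbers in the series, with a gap of a 5.0-fold higher number from compound 1 to compound 3 (0.70 log units; beyond the scatter). Compound 2 `CCOc1ccc(-c2cc(=O)c3c(o2)C(CC)(CC)C(=O)C(CC)=C3O)cc1` reads > 52.4 uM, which is a limit and not a number. Its step is an at least 6.4-fold higher number from compound 1 to compound 2 (0.80 log units; beyond the scatter), with ethoxy in place of isopropyl.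

Compound 4 `CCC1=C(O)c2c(oc(-c3ccc(C)c(Cl)c3)cc2=O)C(CC)(CC)C1=O` carries 3-chloro-4-methylphenyl in place of 2-methoxyphenyl on an aromatic carbon. The most relevant measured change is at this same carbon, where the measured gap is a 5.0-fold higher number from compound 1 to compound 3 (0.70 log units; beyond the scatter). In these three compounds, both groups bearing oxygen give higher numbers than the 4-isopropylphenyl of compound 1, and the entering group has no oxygen. The full gap need not carry over, since the entering group differs from 4-isopropylphenyl. The expected step is a 2.6-fold lower number from compound 3 to compound 4 (0.41 log units; beyond the scatter), a moderate move to a lower number. Compound 4 is estimated at 16 uM, with an expected range of 6 uM to 45 uM.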

Compound 4, concentration for half-maximal effect: 39 uM
Compound 4: middle estimate off by 2.4-fold (0.39 log units), on the low side; measured number inside the range.
By their numbers in this assay, from the lowest: compound 1; then compounds 4 and 3 (each within the scatter of the next). At a limit, above all of these: compound 2.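

In this assay, an aryl group without oxygen stands level with 2-methoxyphenyl: a 1.0-fold lower number from compound 3 to compound 4 (0.02 log units; within the scatter). Oxygen on the aryl group therefore does not account for the gap to compound 1, as compound 4 carries none and still stands apart: a 4.8-fold higher number from compound 1 to compound 4 (0.68 log units; beyond the scatter). Against compound 2 only a floor can be read, an at least 1.3-fold lower number from compound 2 to compound 4 (0.12 log units; that floor lies within the scatter), and the value of compound 2 is a limit and not a number: the limit of > 52.4 uM in this assay, at which 1 of the 4 values shown sits.

Among the aryl groups shown, only the 4-isopropylphenyl of compound 1 gives the lower number, and these compounds do not separate the isopropyl group itself from its place on the ring. On these data alone, it remains open whether a tert-butyl group, a longer alkyl chain or a dimethylamino group in that place would give a number like that of compound 1.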